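This account rests on a few compounds, and the source may have more. Where it says the series, first, only, none or still open, it means among the compounds named here.

Of the compounds shown here, three built on a shared core have been measured in an assay on ileum (strain Hartley) with 5-hydroxytryptamine receptor 3A (Cavia porcellus) as the target; on this read-out higher numbers stand for larger maximal responses and lower numbers for smaller maximal responses. Compound 1 `Cc1cc(Cl)c2oc(N3CCN(C)CC3)nc2c1` gives 0.26 in this assay. Compound 2 `CCc1cc(C)cc2nc(N3CCN(C)CC3)oc12` differs from compound 1 by ethyl in place of chloro on an aromatic carbon, and in this assay compound 2 gives 0.26. The step between these two is no change at the digits printed from compound 1 to compound 2 (within the scatter), so swapping the chloro for an ethyl at that place left the maximal response where it was. Compound 3 `CN1CCN(c2nc3cc(Cl)cc(Cl)c3o2)CC1` differs from compound 1 by chloro in place of methyl on an aromatic carbon, and in this assay compound 3 gives 0.14. Here the step is a number 0.12 lower from compound 1 to compound 3 (beyond the scatter), and compound 3 stands lowest of the three measured numbers, with both others sitting higher by steps that are beyond the scatter.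

Compound 4 `CCc1cc(Cl)cc2nc(N3CCN(C)CC3)oc12` has not yet been measured in this assay. It differs from compound 3 by ethyl in place of chloro on an aromatic carbon. Within the data shown here, this is the same kind of change as the one from compound 1 to compound 2, though not the same: in the earlier pair the place is meta to a methyl group, while in this pair it is meta to a chloro group. For compound 4 the expected step is no change at the digits printed from compound 3 to compound 4 (within the scatter). This expectation rests on the earlier pair, because no change at the digits printed from compound 1 to compound 2 (within the scatter). Compound 4 is therefore estimated at 0.14, expected to fall between 0.05 and 0.26.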

Compound 4, intrinsic activity: the largest response reached, as a fraction of the reference agonist's: 0.17
Beside the measured number, compound 4's estimate is 0.030 below it; low and high end bracket the measured number.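

Putting ethyl in place of chloro on an aromatic carbon of compound 3 gives a number 0.030 higher from compound 3 to compound 4 (within the scatter) in this assay, and this step agrees with the same swap made earlier on a different core: the same change on two cores in this assay, no change at the digits printed (within the scatter) from compound 1 to compound 2 and a number 0.030 higher (within the scatter) from compound 3 to compound 4, 0.030 apart, within the scatter of two such steps. The second new step, chloro in place of methyl, is a number 0.090 lower from compound 2 to compound 4 (within the scatter), and although only the earlier of these two steps is printed as beyond the scatter, the gap separating them is small enough that the two also agree: the same change on two cores in this assay, a number 0.12 lower (beyond the scatter) from compound 1 to compound 3 and a number 0.090 lower (within the scatter) from compound 2 to compound 4, 0.030 apart, within the scatter of two such steps. So, within these four compounds, each change behaves alike on both cores, but that rests on a single pair of steps per change, and it does not show that either change would carry the same way onto any other core or in any other assay.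

The compounds shown leave open what a longer chain such as propyl, a methoxy group or an amine would do at the aromatic carbon where ethyl and chloro have been exchanged. They also leave open whether a carboxylic acid there would move the maximal response by more than the small steps seen so far.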